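The source may hold more compounds than are shown below. What is called first, only, known or untested is meant among the compounds shown, and "the series" means these compounds.

Three compounds have been measured in a functional assay on FaDu cells (Homo sapiens) for cytotoxicity, read by MTT assay, with a stated time of 72 h; a higher number here means that more compound is tolerated, a lower number that less compound is tolerated:

compound 1, `COCCn1cc(C(=O)C(=O)Nc2ccc(OC(F)(F)F)cc2)c2ccccc21`, 487 nM
compound 2, `CC(C)n1cc(C(=O)C(=O)Nc2ccc(OC(F)(F)F)cc2)c2ccccc21`, 8930 nM
compound 3, `COCCn1cc(C(=O)C(=O)Nc2ccnc(OC)c2)c2ccccc21`, 235 nM

Compound 1 and compound 2 differ in one place only, by the change (isopropyl in place of 2-methoxyethyl on an aromatic nitrogen). That single change produces a large step: an 18-fold higher number from compound 1 to compound 2 (1.26 log units; beyond the scatter), a shift well beyond the ordinary scatter of this assay. Compound 3 carries the same 2-methoxyethyl group on its aromatic nitrogen as compound 1 but differs from it in another part of the molecule; the difference between the two cores is not broken down here. Of the three measured values, compound 3 holds the lowest, and its value stands apart from those of both compound 1 and compound 2 by more than the scatter.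

Compound 4, `COc1cc(NC(=O)C(=O)c2cn(C(C)C)c3ccccc23)ccn1`, has not yet been measured. It relates to compound 3 exactly as compound 2 relates to compound 1: the change is isopropyl in place of 2-methoxyethyl on an aromatic nitrogen, and the place where it occurs is described in the same words for both pairs, so it is the same change made on a different core. This change has been observed only once among the compounds shown, so any expectation rests on that single instance.

On that basis, the expected step for compound 4 is an 18-fold higher number from compound 3 to compound 4 (1.25 log units; beyond the scatter), because the earlier instance gave an 18-fold higher number from compound 1 to compound 2 (1.26 log units; beyond the scatter) and the surroundings of the change are the same. Compound 4 is therefore expected to give about 4200 nM in this assay, with a likely range from 1500 nM to 12000 nM.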

Compound 4, concentration lethal to 50% of the cells: 1750 nM
The estimate for compound 4 lay 2.4-fold (0.38 log units) above the measured number; the measured number falls inside the stated range.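

In this assay, isopropyl in place of 2-methoxyethyl on the aromatic nitrogen gives a 7.4-fold higher number from compound 3 to compound 4 (0.87 log units; beyond the scatter), so the change raises the number on the core of compound 3 as it does on the core of compound 1. Set side by side, the two instances agree in direction and cannot be told apart in size: the same change on two cores in this assay, an 18-fold higher number (1.26 log units; beyond the scatter) from compound 1 to compound 2 and a 7.4-fold higher number (0.87 log units; beyond the scatter) from compound 3 to compound 4, 2.5-fold (0.39 log units) apart, within the scatter of two such steps. This supports carrying the change between these two cores, but two instances do not establish that it would behave in the same way on any other core in the series, and they do not show what underlies the step.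

The compounds shown leave open which part of the swap goes with the higher number, the loss of the ether oxygen or the branched shape of the isopropyl group, and a straight propyl chain on the same nitrogen would help to separate the two. On these data alone, it also remains open how a longer chain such as 3-methoxypropyl, or a chain ending in an amine or a carboxylic acid, would compare with 2-methoxyethyl and isopropyl on either core.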